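Removing two methyls from a piperazine on the shared core

The source may hold more compounds than are shown below. What is called first, only, known or untested is meant among the compounds shown, and "the series" means these compounds.

Within the data shown here, compound 2 `C[C@@H]1CN(c2cccc3c2C[C@H](CN(C)[C@H]2CCCc4cccnc42)NC3)C[C@H](C)N1` is one of three compounds measured in an ADME assay on microsomes from liver (Mus musculus) for metabolic stability, read by LC-MS, with a stated time of 10 min; a lower number here means that less of the compound is left, a higher number that more of the compound is left. In this assay compound 2 gives 85.6%. Compound 1 `CCCN(C[C@H]1Cc2c(cccc2N2CCNCC2)CN1)[C@H]1CCCc2cccnc21` gives 87.4%, a number within the usual scatter of compound 2, while compound 3 `CN(C[C@@H]1Cc2c(cccc2N2CCNCC2)CN1)[C@H]1CCCc2cccnc21` gives 54.6%, clearly beyond the scatter on the low side. Compound 2 thus stands with compound 1 and far from compound 3. Compound 4 `CN(C[C@H]1Cc2c(cccc2N2CCNCC2)CN1)[C@H]1CCCc2cccnc21` is not yet measured. It differs from compound 2 in one place: piperazin-1-yl in place of 3,5-dimethylpiperazin-1-yl on an aromatic carbon. Among the measured compounds shown here, no measured pair shows this exact change, so its effect is unknown. Compound 3 carries piperazin-1-yl and gives 54.6%, which suggests caution, yet compound 1 also carries it and gives 87.4%. A modest downward step is expected, a number 11.6 percentage points lower from compound 2 to compound 4 (beyond the scatter), roughly at the edge of the scatter. Compound 4 is therefore estimated at 74%, with a range from 50% to 92%.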

Compound 4, percent of the compound remaining: 19.9%
Compound 4: middle estimate off by 54.1 percentage points, on the high side; measured number outside the range, below it.
By their numbers in this assay, from the lowest: compound 4; then compound 3; then compounds 2 and 1 (each within the scatter of the next).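

On the shared core, piperazin-1-yl in place of 3,5-dimethylpiperazin-1-yl on an aromatic carbon gives, in this assay, a number 65.7 percentage points lower from compound 2 to compound 4 (beyond the scatter), so this position is far from neutral in this assay. The chain on the amine nitrogen also counts: hydrogen in place of ethyl on that chain gives a number 67.5 percentage points lower from compound 1 to compound 4 (beyond the scatter). The stereocentre at a saturated ring carbon counts as well, with a number 34.7 percentage points lower from compound 3 to compound 4 (beyond the scatter), and that step has only one structural difference to point to: the fact that compounds 3 and 4 differ only in the configuration as drawn

Going by these compounds, whether a piperazine with a single methyl, or a morpholine, would stay closer to compound 2 remains open.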